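Three Close Values and a Methoxy Swap

This account rests on a few compounds, and the source may have more. Where it says the series, first, only, none or still open, it means among the compounds named here.

Measured so far in a functional assay on HeLa cells (Homo sapiens) for cytotoxicity, read by resazurin assay, with a stated time of 72 h (on this read-out lower numbers stand for stronger inhibition and higher numbers for weaker inhibition), for three compounds
Compound 1 (`COc1ccc(C(=O)CSC(=S)SCCNC(C)=O)cc1`) gives 11100 nM
Compound 2 (`CCSC(=S)SCC(=O)c1ccc(NS(=O)(=O)c2ccccc2)cc1`) gives 9040 nM
Compound 3 (`CCSC(=S)SCC(=O)c1ccc(S(=O)(=O)Nc2ccc(Cl)cc2)cc1`) gives 6080 nM

In this assay compound 3 gives 6080 nM and so lies within the usual scatter of compound 2 at 9040 nM and of compound 1 at 11100 nM in this comparison. The three values are not separated from one another, although the structures differ.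

Compound 4 (`CCSC(=S)SCC(=O)c1ccc(S(=O)(=O)Nc2ccc(OC)cc2)cc1`) differs from compound 3 in one place (methoxy in place of chloro on an aromatic carbon): methoxy stands in place of chloro on an aromatic carbon, para to a large group. Among the measured compounds shown here, no measured pair differs in one place only, so the data offer no direct guide to this change. The expectation rests on how closely the three measured values sit. The estimated step of a 1.2-fold higher number from compound 3 to compound 4 (0.06 log units; within the scatter) is expected to stay within the scatter, with no clear direction. The estimate for compound 4 is 7000 nM with 3000 nM to 16000 nM as the expected range.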

Compound 4, half-maximal inhibitory concentration: 4320 nM
Estimate against measurement, compound 4: 1.6-fold (0.21 log units) above; low and high end bracket the measured number.
By their numbers in this assay, from the lowest: compounds 4, 3, 2 and 1 (each within the scatter of the next, the first and the last beyond it).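

This is the first pair among the compounds shown that differs in one place only, and in this assay the change from 4-chlorophenyl to 4-methoxyphenyl gives a 1.4-fold lower number from compound 3 to compound 4 (0.15 log units; within the scatter). At this place on the aromatic ring, chloro and methoxy therefore cannot be told apart in this read-out, even though methoxy carries a hydrogen-bond acceptor that chloro does not. No measured evidence bears on why the two groups read alike here.

The compounds shown leave open whether an amine or a carboxylic acid at this same place would also stay within the scatter, since this single pair gives no trend across groups. They also leave open whether a longer chain in place of the ethyl chain would change the value when the rest of the molecule is held fixed.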